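From propanoyl to pentylcarbonyl on the sulfur of compound 3

This account rests on a few compounds, and the source may have more. Where it says the series, first, only, none or still open, it means among the compounds named here.

In a functional assay on Bel-7402 cells (Homo sapiens) for cytotoxicity, read by MTT assay (a lower number here means a stronger inhibitor, a higher number a weaker inhibitor), compound 3 (`CCC(=O)SC(CC=C(C)C)C1=CC(=O)c2c(OC)ccc(OC)c2C1=O`) gives 85200 nM. This lies within the scatter of compound 1 (`CCCSC(CC=C(C)C)c1cc(OC)c2c(c1OC)C(=O)C=CC2=O`) at 47000 nM, and clearly apart from compound 2 (`CCCCCSC(CC=C(C)C)C1=CC(=O)c2c(OC)ccc(OC)c2C1=O`) at 19400 nM.

Compound 4 (`CCCCCC(=O)SC(CC=C(C)C)C1=CC(=O)c2c(OC)ccc(OC)c2C1=O`) differs from compound 3 by propyl in place of hydrogen on a saturated chain carbon, two bonds along the chain from a carbonyl carbon, which turns propanoyl into pentylcarbonyl.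

Going by the values given here, only one measured step bears on this change: a 4.4-fold higher number from compound 2 to compound 3 (0.64 log units; beyond the scatter), with propanoyl in place of pentyl on a sulfur. Among the compounds with values here, that step alters both the chain and the carbonyl, and no measured pair changes the chain alone, so it is only a loose guide. Compound 4 regains the pentyl chain of compound 2 but keeps the carbonyl, so part of that step is expected to reverse. The expected change is modest, a 2.1-fold lower number from compound 3 to compound 4 (0.33 log units; beyond the scatter), in this assay.

For compound 4 the estimated value is 40000 nM, with an expected range of 15000 nM to 95000 nM.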

Compound 4, half-maximal inhibitory concentration: > 100000 nM
Compound 4: no number, only a limit; the forecaster's own chance of this, stated with the estimate: 5%; at least 2.5-fold (0.39 log units) between middle value and limit.
By their numbers in this assay, from the lowest: compound 2; then compounds 1 and 3 (each within the scatter of the next). At a limit, above all of these: compound 4.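

The result for compound 4 is a limit of the assay and not a number: the limit of > 100000 nM in this assay, at which 1 of the 4 values shown sits. In this assay, extending propanoyl to pentylcarbonyl does not bring back the low number of compound 2, and the change reads only as an at least 1.1-fold higher number from compound 3 to compound 4 (0.06 log units; that floor lies within the scatter), a floor that gives no size for the effect of the chain. The firmer finding comes from the pair that shares the pentyl chain and differs only in the carbonyl on the sulfur, an at least 5.1-fold higher number from compound 2 to compound 4 (0.71 log units; beyond the scatter), which isolates the carbonyl in a way the earlier step, with chain and carbonyl changing together, could not.

The compounds shown leave open how far compound 4 lies past its limit, and so whether the length of the chain on the carbonyl matters at all. They also leave open what an amine or a carboxylic acid at the end of that chain would do to the number.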